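A few compounds are considered here, and "the series" means these few. Any claim that something is new, unique, unknown or untested is made for them only; others in the source may bear on it.

Compound 1 `CCOC(=O)c1[nH]c2cc(Cl)ccc2c1/C=N/NC(=O)Cc1cccs1` carries the shared core with a thiophen-2-yl group on the saturated chain carbon bound to the carbonyl carbon. In an assay for inhibition of Polyunsaturated fatty acid lipoxygenase ALOX15 (Homo sapiens), with a stated time of 8 min (on this read-out higher numbers stand for weaker inhibition and lower numbers for stronger inhibition), compound 1 gives > 10000 nM, which is a limit of the assay and not a number. Compound 2 `CCOC(=O)c1[nH]c2cc(Cl)ccc2c1/C=N/NC(=O)COc1cccc2ccccc12` gives > 10000 nM in this assay, again only a limit. Compound 3 `CCOC(=O)c1[nH]c2cc(Cl)ccc2c1/C=N/NC(=O)CCCOc1ccc(Cl)cc1Cl` gives > 10000 nM in this assay, also a limit. Among the measured compounds shown here, compound 1 therefore cannot be placed in any order against compound 2 or compound 3: every value shown sits at the limit of > 10000 nM in this assay, at which 3 of the 3 values shown sit, and no step between measured compounds can be counted.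

Compound 4 `CCOC(=O)c1[nH]c2cc(Cl)ccc2c1/C=N/NC(=O)CNc1cccc([N+](=O)[O-])c1` has not yet been measured in this assay. It differs from compound 1 by (3-nitrophenyl)amino in place of thiophen-2-yl on a saturated chain carbon bound to a carbonyl carbon. With every measured value resting at the limit, the series offers no measured step from which a direction could be read, and nothing in the shown data points to a gain or loss beyond the scatter. The change from compound 1 to compound 4 is expected to amount to a step that the limit leaves unreadable from compound 1 to compound 4 in this assay, a step that would not stand out from the scatter. Compound 4 is thus expected to give about 15000 nM in this assay, with a range from 4000 nM to 60000 nM, and the assay is most likely to report only a limit again.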

Compound 4, half-maximal inhibitory concentration: > 10000 nM
Compound 4: a limit, no number (the forecaster's own chance of this, stated with the estimate: 85%); the middle value does not contradict the limit.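

No step can be read between compound 1 and compound 4 in this assay, since both values are limits of the assay and not numbers: the limit of > 10000 nM in this assay, at which 4 of the 4 values shown sit.

The compounds shown leave open how far any group on the saturated chain carbon bound to the carbonyl carbon changes inhibition, as none of them gives a number.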